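A few compounds are considered here, and "the series" means these few. Any claim that something is new, unique, unknown or untested is made for them only; others in the source may bear on it.

Among the measured compounds shown here, compound 2 `CCCCCn1c(N)nc2c(O)cccc21` gives 5010 nM in an assay on HEK293 cells for agonist activity at Toll-like receptor 8 (Homo sapiens), read by reporter gene assay (on this read-out higher numbers stand for an effect only at larger amounts of compound and lower numbers for an effect already at smaller amounts), and carries the lowest of the two numbers measured so far; its neighbour compound 1 `CCCCCn1c(N)nc2c(N(C)C)cccc21` gives 7120 nM in this assay. For the measured compounds named here, the only step available, a 1.4-fold lower number from compound 1 to compound 2 (0.15 log units; within the scatter), swaps one small group for another at the same aromatic carbon. Compound 3 `CCCCCn1c(N)nc2c(N)cccc21` differs from compound 2 by amino in place of hydroxy on an aromatic carbon. Since that one comparable step stayed within the scatter, the step of a 1.0-fold lower number from compound 2 to compound 3 (0.00 log units; within the scatter) is expected to stay within the scatter as well. Compound 3 is therefore estimated at 5000 nM in this assay, with a range from 2000 nM to 12000 nM.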

Compound 3, half-maximal effective concentration: 6600 nM
The estimate for compound 3 lay 1.3-fold (0.12 log units) below the measured number; measured number inside the range.
By their numbers in this assay, from the lowest: compounds 2, 3 and 1 (each within the scatter of the next).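

Amino at this aromatic carbon reads like both other groups in this assay, with a 1.3-fold higher number from compound 2 to compound 3 (0.12 log units; within the scatter) and a 1.1-fold lower number from compound 1 to compound 3 (0.03 log units; within the scatter). Compound 1, compound 2 and compound 3 therefore cannot be told apart here, so hydroxy, amino and dimethylamino are interchangeable at this carbon on this read-out, and trimming dimethylamino down to plain amino leaves the number within the scatter. Nothing available explains why these groups read alike. Still open, from the compounds shown here alone, is whether this tolerance extends to quite different groups at this carbon, such as a carboxylic acid or a chlorine atom.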